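Removing a Methyl From Compounds Showing No Measurable Binding

The source may report more compounds than this note shows. Statements on the series, on what has been measured and on what is new or still open speak of the compounds shown alone.

Compound 1 `Cc1cnn(C(=O)N(C)CCN(C)Cc2cccc(OCc3ccccc3)c2)c1` gives in an assay on membranes from brain for binding affinity to neutral cholesterol ester hydrolase 1 (Mus musculus), read by fluorescence, with stated times of 1 h and 30 min (on this read-out lower numbers stand for stronger inhibition and higher numbers for weaker inhibition), only a limit, > 100000 nM.
Compound 2 `CN(CCN(C)C(=O)n1cccn1)Cc1cccc(OCc2ccccc2)c1` gives in this assay only a limit, > 100000 nM.
Compound 3 `Cc1cnn(C(=O)NCc2ccc(OC(c3ccccc3)c3ccccc3)cc2)c1` gives in this assay only a limit, > 100000 nM.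

Compound 1 and compound 2 differ by one change, (hydrogen in place of methyl on an aromatic carbon). The step that the two limits leave unreadable from compound 1 to compound 2 cannot be sized because of the limit of > 100000 nM in this assay, at which 3 of the 3 values shown sit. Compound 4 `O=C(NCc1ccc(OC(c2ccccc2)c2ccccc2)cc1)n1cccn1` carries the same change against compound 3, (hydrogen in place of methyl on an aromatic carbon), at the same place. The difference between the two cores of compound 1 and compound 3 is not broken down here.

For compound 4 the outcome in this assay is expected to stay at the limit, since (the limit of > 100000 nM in this assay, at which 3 of the 3 values shown sit). The step that the limit leaves unreadable from compound 3 to compound 4 is therefore expected to be unreadable. The estimate for compound 4 is 200000 nM, between 50000 nM and 1000000 nM.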

Compound 4, half-maximal inhibitory concentration: > 100000 nM
Compound 4 was reported as a limit; the forecaster's own chance of this, stated with the estimate: 85%; the middle value is on the limit's open side.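

No step can be read from compound 3 to compound 4, because both values are limits, not numbers: the limit of > 100000 nM in this assay, at which 4 of the 4 values shown sit.

The compounds shown leave open whether replacing methyl with hydrogen changes inhibition in this assay on either core.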